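The source may report more compounds than this note shows. Statements on the series, on what has been measured and on what is new or still open speak of the compounds shown alone.

In a physicochemical assay for solubility, read by mass spectrometry, in phosphate buffer, with a stated time of 24 h, at pH 7.4 (a lower number here means a less soluble compound, a higher number a more soluble compound), compound 1 `O=C(Nc1ccc(OC(F)(F)F)cc1)NC1CCN(C(=O)C2CCOCC2)CC1` gives 91 ug/mL, compound 2 `Cc1occc1C(=O)N1CCC(NC(=O)Nc2ccc(OC(F)(F)F)cc2)CC1` gives 8.6 ug/mL, and compound 3 `CC[C@H](C)C(=O)N1CCC(NC(=O)Nc2ccc(OC(F)(F)F)c(Br)c2)CC1` gives 0.58 ug/mL. That last number is the lowest of the three and lies beyond the scatter from both others. The unmeasured compound 4 `CC[C@H](C)C(=O)N1CCC(NC(=O)Nc2ccc(OC(F)(F)F)c(Cl)c2)CC1` differs from compound 3 in one place: chloro in place of bromo on an aromatic carbon. The chloro group takes the place of bromo on an aromatic carbon, ortho to a trifluoromethoxy group.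

Within the data shown here, the only measured step between two compounds differing in one place is an 11-fold lower number from compound 1 to compound 2 (1.02 log units; beyond the scatter). This large step, beyond the scatter, concerns 2-methylfuran-3-yl in place of oxan-4-yl on a carbonyl carbon, so it does not bear directly on the change at hand. Among the measured compounds shown here, no measured pair exchanges bromo for chloro. A step within the scatter is therefore expected in this assay, with at most a slight rise. The estimated change is a 1.5-fold higher number from compound 3 to compound 4 (0.17 log units; within the scatter). For compound 4 the expected value is 0.85 ug/mL, with an estimated range from 0.3 ug/mL to 2.4 ug/mL.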

Compound 4, solubility: 0.79 ug/mL
The estimate for compound 4 lay 1.1-fold (0.03 log units) above the measured number, within the range that was stated.
By their numbers in this assay, from the lowest: compounds 3 and 4 (each within the scatter of the next); then compound 2; then compound 1.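

In this assay the exchange of bromo for chloro gives a 1.4-fold higher number from compound 3 to compound 4 (0.13 log units; within the scatter) on an aromatic carbon ortho to a trifluoromethoxy group and meta to a large group. Among these compounds, this is the only measured step at this position, and it shows that this read-out does not separate the two halogens here while the rest of compound 3 stays unchanged. The earlier large step concerned the group on the carbonyl carbon, whereas this one gives the first view of the aromatic position and stays within the scatter. Nothing given here offers an explanation for this result.

The compounds shown leave open whether a different group at this aromatic carbon, such as a methyl, a methoxy group, a nitrile or an amine, would shift the number beyond the scatter. They also leave open whether the same exchange of bromo for chloro would read alike with oxan-4-yl or 2-methylfuran-3-yl on the carbonyl carbon.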